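The compounds below may be only part of what the source reports. "The series", "measured", "known", "first", "only" and "open" are said of these compounds alone.

Compound 1 `CS(=O)(=O)c1ccc(-c2cnc(N)c(-c3ccc(C#N)cc3)c2)cc1`: 1.6 ug/mL
Compound 2 `CS(=O)(=O)c1ccc(-c2cnc(N)c(-c3ccc(S(C)(=O)=O)cc3)c2)cc1`: 6.3 ug/mL

In a physicochemical assay for solubility, read by nephelometry, in phosphate buffer, measured as kinetic solubility, with a stated time of 30 min, at pH 6.5 (on this read-out higher numbers stand for higher solubility and lower numbers for lower solubility), compound 2 has the higher of the two numbers, at 6.3 ug/mL. Compound 3 `CS(=O)(=O)c1ccc(-c2cnc(N)c(-c3ccc(C(N)=O)cc3)c2)cc1` has carbamoyl in place of methylsulfonyl on an aromatic carbon. Among the measured compounds shown here, the only measured step that bears on this change is a 3.9-fold higher number from compound 1 to compound 2 (0.60 log units; beyond the scatter), a modest step beyond the scatter, with methylsulfonyl in place of cyano. For the measured compounds named here, no measurement yet covers carbamoyl, so that step gives only a rough sense of size and no firm direction. The expected step in this assay is a 1.6-fold lower number from compound 2 to compound 3 (0.20 log units; within the scatter), not beyond the scatter. Compound 3 is estimated at 4 ug/mL, with an expected range of 1.5 ug/mL to 12 ug/mL.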

Compound 3, solubility: 25 ug/mL
Estimate against measurement, compound 3: 6.3-fold (0.80 log units) below, and the stated range ends below it.
By their numbers in this assay, from the lowest: compound 1; then compound 2; then compound 3.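

In this assay, carbamoyl on this aromatic carbon gives a 4.0-fold higher number from compound 2 to compound 3 (0.60 log units; beyond the scatter), and a 16-fold higher number from compound 1 to compound 3 (1.19 log units; beyond the scatter). The three groups at this position now fall in the order cyano, methylsulfonyl, carbamoyl, with every step beyond the scatter, so methylsulfonyl no longer marks the top of the range. Unlike methylsulfonyl, carbamoyl counts a hydrogen-bond donor, but no available measurement explains the rise. Still open, going by these compounds, is how an amine or a carboxylic acid on the same carbon would compare, and whether the carbamoyl result would survive a methyl group on its nitrogen.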